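This account rests on a few compounds, and the source may have more. Where it says the series, first, only, none or still open, it means among the compounds named here.

In a functional assay on DU-145 cells (Homo sapiens) for antiproliferative activity, read by MTT assay, with a stated time of 48 h (on this read-out lower numbers stand for stronger inhibition and higher numbers for weaker inhibition), compound 1 (`CN1C(=O)C(O)(Cc2nnn[nH]2)c2ccccc21`) gives 36800 nM, and compound 3 (`O=C1N(Cc2ccc(Br)cc2)c2ccc(Cl)cc2C1(O)Cc1nnn[nH]1`) gives 19500 nM, so the two lie within the usual scatter of each other. Compound 2 (`CCN1C(=O)C(O)(Cc2nnn[nH]2)c2ccccc21`) gives > 100000 nM, which is a limit and not a number. Compound 4 (`CN1C(=O)C(O)(Cc2nnn[nH]2)c2cc(Br)ccc21`) has not been measured and differs from compound 1 as follows: bromo in place of hydrogen on an aromatic carbon. Among the compounds with values here, the only measured step, an at least 2.7-fold higher number from compound 1 to compound 2 (0.43 log units; beyond the scatter), changes the chain on the amide-type nitrogen and not the aromatic ring, so it says little about this change. Compound 3 carries chloro on the aromatic ring among several other differences, and its value of 19500 nM offers only loose guidance. The expected change is small, a 1.5-fold lower number from compound 1 to compound 4 (0.17 log units; within the scatter), with no step beyond the scatter. For compound 4 the estimated value is 25000 nM, with an expected range from 9000 nM to 70000 nM.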

Compound 4, half-maximal inhibitory concentration: > 100000 nM
Compound 4: only a limit was reported; the forecaster's own chance of this, stated with the estimate: 12%; middle value at least 4.0-fold (0.60 log units) away from the limit.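

This aromatic position is not indifferent to substitution in this assay: bromo in place of hydrogen gives an at least 2.7-fold higher number from compound 1 to compound 4 (0.43 log units; beyond the scatter). The earlier compounds shown here showed such a step only for a change in the chain on the ring nitrogen, not for one on the aromatic ring. The true size of the step stays unknown, since the reading for compound 4 is only a limit: the limit of > 100000 nM in this assay, at which 2 of the 4 values shown sit.

From the compounds shown here alone, whether fluoro, methoxy or an amine at this position would behave like bromo stays open. Compound 3 carries chloro on the aromatic ring but differs in several other places, and gives no clean comparison.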